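From Isopropoxy to Methoxy: Following Compound 3

The source may report more compounds than this note shows. Statements on the series, on what has been measured and on what is new or still open speak of the compounds shown alone.

In a functional assay on HCT-116 cells (Homo sapiens) for cytotoxicity, read by MTT assay, with a stated time of 48 h, in the presence of a further agent that is not named here (a lower number here means that less compound is needed, a higher number that more compound is needed for the effect), compound 1 (`COc1ccc(-c2cc(NNC(=O)Nc3cc(Cl)nc(OC(C)C)c3)nc3c2cnn3C)cc1`) gives 39800 nM and compound 2 (`Cc1nn(C)c2nc(NNC(=O)Nc3cc(Cl)nc(Cl)c3)cc(-c3ccccc3)c12`) gives 80000 nM. These two numbers lie within the usual scatter of each other, so compound 1 does not stand apart from compound 2.

Compound 3 (`COc1ccc(-c2cc(NNC(=O)Nc3cc(Cl)nc(OC)c3)nc3c2cnn3C)cc1`) keeps the core of compound 1 but carries methyl in place of isopropyl on an oxygen on an aromatic ring, which turns 2-chloro-6-isopropoxypyridin-4-yl into 2-chloro-6-methoxypyridin-4-yl: methyl in place of isopropyl on an oxygen on an aromatic ring. For the measured compounds named here, no measured pair of compounds shows what this change does on its own. With only the value of compound 1 at 39800 nM as an anchor, no step beyond the scatter is expected in this assay. The estimated change is small, a 1.1-fold higher number from compound 1 to compound 3 (0.05 log units; within the scatter). For compound 3 the expected value is 45000 nM, with an estimated range from 15000 nM to 100000 nM.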

Compound 3, half-maximal effective concentration: 54200 nM
The estimate for compound 3 lay 1.2-fold (0.08 log units) below the measured number, within the range that was stated.
By their numbers in this assay, from the lowest: compounds 1, 3 and 2 (each within the scatter of the next).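

For the compounds shown here, this pair gives the first direct reading at this position: methyl in place of isopropyl on an oxygen on an aromatic ring gives a 1.4-fold higher number from compound 1 to compound 3 (0.13 log units; within the scatter) in this assay and so does not separate the two groups. Isopropoxy and methoxy therefore cannot be told apart here, although this reading rests on a single pair with the core of compound 1 held fixed. No further measurement is at hand that would bear on this result.

From the compounds shown here alone, whether this position responds to any group remains open: an amine, a carboxylic acid or a longer chain in place of the isopropoxy could give a step beyond the scatter, or none. Also open, going by these compounds, is whether the same exchange would read alike on another core.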